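A Formyl Ester in Place of the Silyl Group

The source may report more compounds than this note shows. Statements on the series, on what has been measured and on what is new or still open speak of the compounds shown alone.

Measured so far in a functional assay on KB cells (Homo sapiens) for cytotoxicity, read by sulforhodamine B assay; a lower number here means a stronger inhibitor, a higher number a weaker inhibitor:
compound 1 `C=C1[C@@H](OC(C)=O)C[C@@H]2[C@](C)(CO[Si](C)(C)C(C)(C)C)[C@H](OC(C)=O)CC[C@@]2(C)[C@@H]1C[C@@H](Nc1ccccc1)C1=CCOC1=O`: 5710 nM
compound 2 `C=C1[C@@H](OC(C)=O)C[C@@H]2[C@](C)(CO[Si](C)(C)C(C)(C)C)[C@H](OC(C)=O)CC[C@@]2(C)[C@@H]1C[C@@H](Nc1ccc(OC)cc1)C1=CCOC1=O`: 5630 nM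
compound 3 `C=C1[C@@H](OC(C)=O)C[C@@H]2[C@](C)(COC=O)[C@H](OC(C)=O)CC[C@@]2(C)[C@@H]1C[C@@H](Nc1ccc(OC)cc1)C1=CCOC1=O`: 32700 nM

Compound 1 holds the second highest of these three numbers. Its nearest neighbour is compound 2, the step of a 1.0-fold lower number from compound 1 to compound 2 (0.01 log units; within the scatter); its furthest is compound 3, whose value lies well above that of compound 1.

Compound 4 `C=C1[C@@H](OC(C)=O)C[C@@H]2[C@](C)(COC=O)[C@H](OC(C)=O)CC[C@@]2(C)[C@@H]1C[C@@H](Nc1ccccc1)C1=CCOC1=O` differs from compound 1 by a group of 2 heavy atoms (1 carbon, 1 oxygen; no ring) in place of a group of 7 heavy atoms (6 carbon, 1 silicon; no ring), on an oxygen on a saturated carbon. Within the data shown here, the one measured step that bears on this change is a 5.8-fold higher number from compound 2 to compound 3 (0.76 log units; beyond the scatter), the same exchange made on the same oxygen. Compound 4 is therefore expected to show a comparable rise, a 5.8-fold higher number from compound 1 to compound 4 (0.76 log units; beyond the scatter). The estimate for compound 4 is 33000 nM, with a range from 15000 nM to 70000 nM.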

Compound 4, half-maximal inhibitory concentration: 32100 nM
For compound 4 the middle estimate is 1.0-fold (0.01 log units) above the measured one, within the range that was stated.
By their numbers in this assay, from the lowest: compounds 2 and 1 (each within the scatter of the next); then compounds 4 and 3 (each within the scatter of the next).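

In this assay, the exchange of formyl for the group of 7 heavy atoms on this oxygen now holds on a second core, with a 5.6-fold higher number from compound 1 to compound 4 (0.75 log units; beyond the scatter), so the rise no longer rests on a single pair: the same change on two cores in this assay, a 5.8-fold higher number (0.76 log units; beyond the scatter) from compound 2 to compound 3 and a 5.6-fold higher number (0.75 log units; beyond the scatter) from compound 1 to compound 4, 1.0-fold (0.01 log units) apart, within the scatter of two such steps. Methoxy in place of hydrogen on the aromatic carbon also leaves the number unchanged with formyl on the oxygen, as a 1.0-fold lower number from compound 3 to compound 4 (0.01 log units; within the scatter) shows: the same change on two cores in this assay, a 1.0-fold lower number (0.01 log units; within the scatter) from compound 1 to compound 2 and a 1.0-fold higher number (0.01 log units; within the scatter) from compound 4 to compound 3, 1.0-fold (0.01 log units) apart, within the scatter of two such steps.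

The compounds shown leave open whether the rise comes from the arrival of formyl or the loss of the group it replaces. A free hydroxyl or an acetyl on this oxygen would separate the two.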